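The compounds below may be only part of what the source reports. "The series", "measured", "known", "first", "only" and "open" are said of these compounds alone.

Among the measured compounds shown here, compound 3 `COc1cc(OC)c2c(=O)c(OCCCN3CCN(C)CC3)c(-c3cc(OC)c(OC)c(OC)c3)oc2c1` stands as the weakest of the three measured members in a functional assay on MDA-MB-231 cells (Homo sapiens) for cytotoxicity, read by MTT assay, with a stated time of 38 h; a higher number here means a weaker inhibitor, a lower number a stronger inhibitor: compound 3 gives 30100 nM, and the two steps that reach it are a 9.9-fold higher number from compound 1 to compound 3 (1.00 log units; beyond the scatter) and a 16-fold higher number from compound 2 to compound 3 (1.21 log units; beyond the scatter). Compound 1 `COc1cc(OC)c2c(=O)c(OCCCCN3CCCCC3)c(-c3cc(OC)c(OC)c(OC)c3)oc2c1` gives 3030 nM, compound 2 `COc1cc(OC)c2c(=O)c(OCC(=O)N/N=C/c3ccco3)c(-c3cc(OC)c(OC)c(OC)c3)oc2c1` gives 1860 nM, and between those two the step is a 1.6-fold lower number from compound 1 to compound 2 (0.21 log units; within the scatter), so compound 1 and compound 2 cannot be ordered against each other.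

Compound 4 `COc1cc(OC)c2c(=O)c(OCC(=O)N/N=C/c3ccccn3)c(-c3cc(OC)c(OC)c(OC)c3)oc2c1` is not yet measured. Relative to compound 3 the change is a group of 11 heavy atoms (7 carbon, 3 nitrogen, 1 oxygen; one six-membered aromatic ring with 1 hetero atom) in place of a group of 9 heavy atoms (7 carbon, 2 nitrogen; one six-membered non-aromatic ring with 2 hetero atoms), on a saturated chain carbon bound to an oxygen on an aromatic ring. The step that bears most directly on it is a 16-fold higher number from compound 2 to compound 3 (1.21 log units; beyond the scatter). The group entering in compound 4 resembles the group carried by compound 2, the two differing only in the aromatic ring at the end of the chain. The step of a 9.9-fold higher number from compound 1 to compound 3 (1.00 log units; beyond the scatter) points the same way, showing that leaving the group of compound 3 has so far brought a lower number. For the measured compounds named here, no measured pair separates a five-membered from a six-membered aromatic ring in this position, so the range is kept wide. Compound 4 is therefore expected to return close to the level of compound 2, an estimated step of a 14-fold lower number from compound 3 to compound 4 (1.14 log units; beyond the scatter). The estimate for compound 4 is 2200 nM, with a range from 700 nM to 7000 nM.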

Compound 4, half-maximal inhibitory concentration: 9890 nM
Compound 4: middle estimate off by 4.5-fold (0.65 log units), on the low side; measured number above the stated range.
By their numbers in this assay, from the lowest: compounds 2 and 1 (each within the scatter of the next); then compound 4; then compound 3.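

In this assay, among the compounds shown here, the ring on the carbon with a double bond to nitrogen proves to matter: pyridin-2-yl in place of furan-2-yl gives a 5.3-fold higher number from compound 2 to compound 4 (0.73 log units; beyond the scatter) and is the first measured pair that isolates this ring at this place. Leaving 2-(4-methylpiperazin-1-yl)ethyl for the pyridine-bearing chain still gives a 3.0-fold lower number from compound 3 to compound 4 (0.48 log units; beyond the scatter), while the same chain compared with the piperidine-bearing chain gives a 3.3-fold higher number from compound 1 to compound 4 (0.51 log units; beyond the scatter), so compound 4 does not share the position that compound 2 holds, within the scatter, with compound 1. The chain type alone therefore does not set the level in this small set, and no measurement is available that accounts for the difference made by the ring.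

On these data alone, with only furan-2-yl and pyridin-2-yl compared, it remains open where phenyl, thiophen-2-yl or pyridin-4-yl on the same carbon would fall in this assay and whether the ring nitrogen of pyridin-2-yl tracks with the higher number. As far as these compounds go, it also remains open how a morpholine on the chain of compound 3 would compare with the 4-methylpiperazin-1-yl group.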